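The compounds below may be only part of what the source reports. "The series", "measured", "known", "first", "only" and "open" are said of these compounds alone.

Among the measured compounds shown here, compound 1 `CCOC(=O)/C=C/c1ccc(NC(=O)C2(NC(=O)c3ccc4c(C5CCCC5)c(-c5ncc(Cl)cn5)n(C)c4c3)CCC2)cc1OCC` is the shorter-lived of the two compounds measured so far: in an ADME assay on stomach for pharmacokinetics, in simulated gastric fluid (a lower number here means that the compound disappears faster, a higher number that the compound lasts longer), compound 1 gives 0.333 h. For the measured compounds named here, its only measured neighbour is compound 2 `CCCOC(=O)/C=C/c1ccc(NC(=O)C2(NC(=O)c3ccc4c(C5CCCC5)c(-c5ncc(Cl)cn5)n(C)c4c3)CCC2)cc1OCC`, which in this assay gives 2.23 h, so that a 6.7-fold higher number from compound 1 to compound 2 (0.83 log units; beyond the scatter) marks the one step known here, a change at the alcohol end of the ester chain.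

Compound 3 `CCOc1cc(NC(=O)C2(NC(=O)c3ccc4c(C5CCCC5)c(-c5ncc(Cl)cn5)n(C)c4c3)CCC2)ccc1/C=C/C(=O)OCC(Cl)(Cl)Cl` alters the same end of compound 1 in a different way: trichloromethyl in place of methyl on a saturated chain carbon bound to an oxygen next to a carbonyl group. Going by the values given here, the step from compound 1 to compound 2 shows that a change at this part of the molecule can shift the half-life beyond the scatter, but the present change has no measured counterpart, so its direction cannot be read from the data. Compound 3 is therefore expected to stay near compound 1, with an estimated step of a 1.5-fold higher number from compound 1 to compound 3 (0.18 log units; within the scatter). The estimate for compound 3 in this assay is 0.5 h, within a range from 0.12 h to 2 h.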

Compound 3, half-life: 1.75 h
Beside the measured number, compound 3's estimate is 3.5-fold (0.54 log units) below it; the measured number falls inside the stated range.
By their numbers in this assay, from the lowest: compound 1; then compounds 3 and 2 (each within the scatter of the next).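

In this assay, compound 1 now stands apart from two different changes at the alcohol end of its ester, since trichloromethyl in place of methyl gives a 5.3-fold higher number from compound 1 to compound 3 (0.72 log units; beyond the scatter), a step of similar size to a 6.7-fold higher number from compound 1 to compound 2 (0.83 log units; beyond the scatter). The two altered esters cannot be told apart, with a 1.3-fold lower number from compound 2 to compound 3 (0.11 log units; within the scatter). At this position, then, the short half-life is not tied to one single replacement: both the ethyl on that carbon in compound 2 and the much larger trichloromethyl in compound 3 leave compound 1 as the shortest-lived of the three.

Nothing available here explains either step. Going by these compounds, whether the half-life keeps the same level with a longer chain such as butyl, or with a 2,2,2-trifluoroethyl ester, remains open.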